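A few compounds are considered here, and "the series" means these few. Any claim that something is new, unique, unknown or untested is made for them only; others in the source may bear on it.

Measured compounds:
- compound 1 `O=C(CCCCCONC(=O)Nc1cccc2cccnc12)NO`: 1100 nM
- compound 2 `Cc1ccc2cccc(NC(=O)NOCCCCCC(=O)NO)c2n1`: 2200 nM

In a functional assay on CAL-27 cells (Homo sapiens) for antiproliferative activity, read by MTT assay, with a stated time of 72 h (on this read-out lower numbers stand for stronger inhibition and higher numbers for weaker inhibition), compound 1 gives 1100 nM. For the measured compounds named here, only one other measurement stands beside it, and the two cannot be told apart: a 2.0-fold higher number from compound 1 to compound 2 (0.30 log units; within the scatter). Going by the values given here, compound 1 therefore sits level with its sole neighbour, and the numbers do not set it apart.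

The next compound, compound 3 `COc1cc(NC(=O)NOCCCCCC(=O)NO)c2ncccc2c1`, keeps the chain and the core of compound 1 and changes one place: methoxy in place of hydrogen on an aromatic carbon.

A single measured step bears on this change, and it is only a loose guide, since it brings in methyl rather than methoxy: a 2.0-fold higher number from compound 1 to compound 2 (0.30 log units; within the scatter). Among the compounds with values here, no measured compound carries methoxy, so the data say nothing directly about that group. With this one precedent staying within the scatter, no step beyond the scatter is expected in this assay, although a slightly higher number seems the likelier direction. The expected step is a 1.4-fold higher number from compound 1 to compound 3 (0.13 log units; within the scatter). For compound 3 the estimated value is 1500 nM, with an expected range of 600 nM to 3800 nM.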

Compound 3, half-maximal inhibitory concentration: 900 nM
For compound 3 the middle estimate is 1.7-fold (0.22 log units) above the measured one; measured number inside the range.
By their numbers in this assay, from the lowest: compounds 3, 1 and 2 (each within the scatter of the next, the first and the last beyond it).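

With methoxy in place of hydrogen on an aromatic carbon of the six-membered ring of carbon only, compound 3 cannot be told apart from compound 1 in this assay (a 1.2-fold lower number from compound 1 to compound 3 (0.09 log units; within the scatter)). For the compounds shown here, this gives the first direct reading for methoxy and for this position, meta to a large group and para to a fused ring, as the only earlier step concerned methyl at a different place on the core. Methoxy is therefore accommodated at this position without a step beyond the scatter, and nothing available accounts for that outcome.

The compounds shown leave open whether this tolerance extends to other groups at the same position, such as fluorine, an amine or a carboxylic acid, or to a larger ether such as benzyloxy. They also leave open whether methoxy would behave the same way at the place that carries methyl in compound 2, or on a compound with a longer chain than the one shared here.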